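The compounds below may be only part of what the source reports. "The series", "measured", "known", "first", "only" and "open" are said of these compounds alone.

Compound 3 `C#Cc1cccc(Nc2ncnc3ccc(NC(=S)Nc4ccc(S(N)(=O)=O)cc4)cc23)c1` carries a 3-ethynylphenyl group on the aniline nitrogen of its core. In a functional assay on A-431 cells (Homo sapiens) for antiproliferative activity, read by MTT assay, with a stated time of 72 h (a higher number here means a weaker inhibitor, a lower number a stronger inhibitor), compound 3 gives 15300 nM, the highest of the three numbers here; compound 1 `COc1cc2ncnc(Nc3cccc(Br)c3)c2cc1OCCCCC(=O)Nc1ccc(S(N)(=O)=O)cc1` gives 9750 nM, a gap within the scatter, while compound 2 `COc1cc2ncnc(Nc3ccc(Cl)cc3)c2cc1OCCCCC(=O)Nc1ccc(S(N)(=O)=O)cc1` gives 7120 nM, a gap beyond it. Compound 4 `Cc1ccc(Nc2ncnc3ccc(NC(=S)Nc4ccc(S(N)(=O)=O)cc4)cc23)cc1` differs from compound 3 only by 4-methylphenyl in place of 3-ethynylphenyl on a nitrogen on an aromatic ring. For the measured compounds named here, the one comparable step, swapping the aryl group on the same kind of nitrogen in a different core, was a 1.4-fold lower number from compound 1 to compound 2 (0.14 log units; within the scatter). Such a swap changed little, so a step of a 1.0-fold lower number from compound 3 to compound 4 (0.01 log units; within the scatter) is expected, with no change beyond the scatter. Compound 4 is therefore estimated at 15000 nM, within 6000 nM to 40000 nM.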

Compound 4, half-maximal inhibitory concentration: 40000 nM
For compound 4 the middle estimate is 2.7-fold (0.43 log units) below the measured one; measured number inside the range.
By their numbers in this assay, from the lowest: compounds 2, 1 and 3 (each within the scatter of the next, the first and the last beyond it); then compound 4.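

In this assay, the swap to 4-methylphenyl gives a 2.6-fold higher number from compound 3 to compound 4 (0.42 log units; beyond the scatter), so on this core the aryl group on this nitrogen can move the number beyond the scatter, unlike the swap in the other core, a 1.4-fold lower number from compound 1 to compound 2 (0.14 log units; within the scatter). The change replaces the ethynyl group with a methyl group and also differs in the numbering of the substituent on the ring, so this single step cannot separate the two. No measurement shown here explains the step.

Going by these compounds, whether the substituent or its ring position matters more remains open. A 3-methylphenyl or 4-ethynylphenyl group on this nitrogen would help separate them.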